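A Second Pyridine Enters the Same Hydroxamate Scaffold

The source may hold more compounds than are shown below. What is called first, only, known or untested is meant among the compounds shown, and "the series" means these compounds.

Among the measured compounds shown here, compound 2 `O=C(NO)c1ccc(COc2c(-c3cccnc3)c3ccccc3n(Cc3ccccc3)c2=O)cc1` gives the lowest number of the two measured so far in an assay on Sf9 cells for inhibition of protein deacetylase HDAC6 (Homo sapiens), read by fluorescence, with a stated time of 90 min (a higher number here means a weaker inhibitor, a lower number a stronger inhibitor), with 25.6 nM, while compound 1 `O=C(NO)c1ccc(COc2c(-c3ccccc3)c3ccccc3n(Cc3ccncc3)c2=O)cc1` gives 84.1 nM in this assay; these two compounds differ in two places, so their gap is noted without being assigned to either change. Compound 3 `O=C(NO)c1ccc(COc2c(-c3cccnc3)c3ccccc3n(Cc3ccncc3)c2=O)cc1` has not been measured. Its difference from compound 2 is pyridin-4-yl in place of phenyl on a saturated chain carbon bound to an aromatic nitrogen. For the measured compounds named here, no measured pair isolates this single change, so the direction is uncertain, and only a modest weakening, or none beyond the scatter, is expected. The expected step is a 1.5-fold higher number from compound 2 to compound 3 (0.17 log units; within the scatter). For compound 3 the estimate is 38 nM, within 13 nM to 110 nM.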

Compound 3, half-maximal inhibitory concentration: 45.3 nM
The estimate for compound 3 lay 1.2-fold (0.08 log units) below the measured number; low and high end bracket the measured number.
By their numbers in this assay, from the lowest: compounds 2, 3 and 1 (each within the scatter of the next, the first and the last beyond it).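

In this assay, pyridin-4-yl in place of phenyl on a saturated chain carbon bound to an aromatic nitrogen can now be read as a single change, and it gives a 1.8-fold higher number from compound 2 to compound 3 (0.25 log units; within the scatter). Pyridin-3-yl in place of phenyl on an aromatic carbon can also be read alone, giving a 1.9-fold lower number from compound 1 to compound 3 (0.27 log units; within the scatter). Neither single change stands clear of the scatter at its position. Nothing available explains either step. From the compounds shown here alone, whether an amine or a carboxylic acid on the benzyl ring would shift the number at that position remains open.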